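The source may hold more compounds than are shown below. What is called first, only, known or untested is meant among the compounds shown, and "the series" means these compounds.

Four compounds sharing one core are considered here, and two of them have numbers in an ADME assay on a cell-free system (plasma, Mus musculus); on this read-out higher numbers stand for a larger free fraction and lower numbers for a smaller free fraction. In that assay compound 1 (`COCCN(C)S(=O)(=O)c1ccc(C)c(C#Cc2cc(Cl)ccc2OCC(=O)O)c1`) gives 0.007, and compound 2 (`Cc1ccc(S(=O)(=O)N(C)C(C)C)cc1C#Cc1cc(Cl)ccc1OCC(=O)O`) gives 0.005. Compound 3 (`COCCNS(=O)(=O)c1ccc(C)c(C#Cc2cc(Cl)ccc2OCC(=O)O)c1`) offers no such starting point: in this assay compound 3 stands as "not determined" (no result reported), so it has no single number. The step followed here leads from compound 3 to compound 4 (`Cc1ccc(S(=O)(=O)NC(C)C)cc1C#Cc1cc(Cl)ccc1OCC(=O)O`), with isopropyl in place of 2-methoxyethyl on a sulfonamide nitrogen. Going by the values given here, only one measured step bears on this change, the same exchange in another pair of compounds, which amounted to a 1.4-fold lower number from compound 1 to compound 2 (0.15 log units; within the scatter). Among the compounds with values here, that single step lies within the scatter, and it is the only evidence available for this exchange. No step beyond the scatter is therefore expected in this assay, and no direction can be assigned to the change. With no number for compound 3, the expectation has to rest on compound 1 at 0.007 and compound 2 at 0.005. Compound 4 is accordingly expected at about 0.006, with an estimated range from 0.003 to 0.012.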

Compound 4, unbound fraction: 0.01
Beside the measured number, compound 4's estimate is 1.7-fold (0.22 log units) below it; measured number inside the range.
By their numbers in this assay, from the lowest: compounds 2, 1 and 4 (each within the scatter of the next).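

The result brings a new exchange at this position into view: in this assay hydrogen in place of methyl on a sulfonamide nitrogen appears as a small step (a 2.0-fold higher number from compound 2 to compound 4 (0.30 log units; within the scatter)) that stays within the scatter. The broader exchange on the sulfonyl sulfur, isopropylamino in place of (2-methoxyethyl)(methyl)amino, also stays within the scatter (a 1.4-fold higher number from compound 1 to compound 4 (0.15 log units; within the scatter)), so across compound 1, compound 2 and compound 4 neither change to the groups on this nitrogen gives a step beyond it, and all three compounds keep a small free fraction. Nothing shown here offers an explanation for how these numbers sit together.

Compound 3 has no number in this assay and the step from it to compound 4 cannot be read, so the exchange of 2-methoxyethyl for isopropyl on a nitrogen that also carries hydrogen remains without a direct reading. The compounds shown also leave open whether a larger change on this nitrogen, such as an amine, a hydroxyl, a longer chain or a ring, would give a step beyond the scatter.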